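Changing the Ring on the Thiocarbonyl Carbon

This account rests on a few compounds, and the source may have more. Where it says the series, first, only, none or still open, it means among the compounds named here.

Of the compounds shown here, three sharing one core have been tested in a functional assay on K562 cells (Homo sapiens) for cytotoxicity; on this read-out higher numbers stand for weaker inhibition and lower numbers for stronger inhibition. Compound 1 `CCN(CC)C(=S)SCc1ccc2nc(C)nc(O)c2c1` gives 4400 nM, compound 2 `Cc1nc(O)c2cc(CS/C(S)=N/C3CCCCC3)ccc2n1` gives 31000 nM, and compound 3 `Cc1nc(O)c2cc(CSC(=S)N3CCCCC3)ccc2n1` gives 11300 nM, which puts compound 3 second highest of the three, above compound 1 and beneath compound 2. Going by the values given here, the only step that alters a single place, a 2.6-fold higher number from compound 1 to compound 3 (0.41 log units; beyond the scatter), was modest. Compound 4 `Cc1nc(O)c2cc(CSC(=S)N3CC(C)OC(C)C3)ccc2n1` differs from compound 3 by 2,6-dimethylmorpholin-4-yl in place of piperidin-1-yl on a thiocarbonyl carbon. Because a 2.6-fold higher number from compound 1 to compound 3 (0.41 log units; beyond the scatter) was modest, a further exchange of the ring on the thiocarbonyl carbon is expected to move this assay by at most a modest amount, with the direction uncertain. Compound 4 is therefore estimated at 14000 nM, with a range from 5000 nM to 40000 nM, which is expected to amount to a 1.2-fold higher number from compound 3 to compound 4 (0.09 log units; within the scatter).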

Compound 4, half-maximal inhibitory concentration: 3700 nM
Estimate against measurement, compound 4: 3.8-fold (0.58 log units) above; the whole stated range lies above it.
By their numbers in this assay, from the lowest: compounds 4 and 1 (each within the scatter of the next); then compound 3; then compound 2.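

In this assay, changing the ring on the thiocarbonyl carbon can lower the number as well as raise it: 2,6-dimethylmorpholin-4-yl in place of piperidin-1-yl gives a 3.1-fold lower number from compound 3 to compound 4 (0.48 log units; beyond the scatter) on this read-out. The same ring in place of diethylamino gives a 1.2-fold lower number from compound 1 to compound 4 (0.08 log units; within the scatter), so these two groups cannot be told apart here. No measurement at hand explains either step.

The compounds shown do not separate the ring oxygen from the two methyl groups, which plain morpholin-4-yl could do. As far as these compounds go, how piperazin-1-yl or a ring bearing a carboxylic acid would read also remains open.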